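This account rests on a few compounds, and the source may have more. Where it says the series, first, only, none or still open, it means among the compounds named here.

Compound 1 `CC(C)(O)c1ccc(-c2cnc3c(n2)N(CC2CCOCC2)C(=O)CN3)cn1` gives 1600 nM in an ADME assay on the whole organism for pharmacokinetics, with Rattus norvegicus as the target, at a dose of 5 mg/kg by the oral route; on this read-out higher numbers stand for higher exposure at the dose given and lower numbers for lower exposure.
Compound 2 `CO[C@H]1CC[C@H](N2CC(=O)Nc3ncc(-c4ccc(C(C)(C)O)nc4)nc32)CC1` gives 6300 nM in this assay.

Of the two numbers measured in this assay, compound 2 stands highest; its nearest neighbour, compound 1, lies beyond the scatter below it. Compound 3 `CO[C@H]1CC[C@H](CN2CC(=O)Nc3ncc(-c4ccc(C(C)(C)O)nc4)nc32)CC1` is not yet measured and differs from compound 2 in one place: (4-methoxycyclohexyl)methyl in place of 4-methoxycyclohexyl on a nitrogen on an aromatic ring in a ring. Within the data shown here, no step between measured compounds differing in one place is known, so the expectation rests on compound 2 alone. The change is expected to shift the number little, within the scatter, so that the step of a 1.4-fold lower number from compound 2 to compound 3 (0.15 log units; within the scatter) is expected. Compound 3 is estimated at 4500 nM, with a range from 1500 nM to 13000 nM.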

Compound 3, maximal plasma concentration: 700 nM
Estimate against measurement, compound 3: 6.4-fold (0.81 log units) above, and the stated range ends above it.
By their numbers in this assay, from the lowest: compound 3; then compound 1; then compound 2.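

On the ring nitrogen, exposure proves sensitive to a small change: (4-methoxycyclohexyl)methyl in place of 4-methoxycyclohexyl gives a 9.0-fold lower number from compound 2 to compound 3 (0.95 log units; beyond the scatter) in this assay, a step beyond the scatter. The two groups have the same kind of ring and the same hydrogen-bond counts, so this position does not tolerate every change that leaves those features alike. Nothing available explains the drop. As far as these compounds go, whether a longer chain or an amine on this nitrogen would lower the number further, or restore it, stays open.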